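The compounds below may be only part of what the source reports. "The series", "measured", "known", "first", "only" and "open" are said of these compounds alone.

Measured compounds:
compound 1, `CCOC(=O)N1CCC(CN2CC[C@H](NC(=O)c3cc(Cl)c(N)cc3OC)[C@H](OC)C2)CC1`, 377 nM in an assay on COS-7 cells for displacement of a labelled ligand from 5-hydroxytryptamine receptor 4 (Homo sapiens), read by scintillation counting, with a stated time of 30 min; on this read-out higher numbers stand for weaker inhibition and lower numbers for stronger inhibition
compound 2, `COc1cc(N)c(Cl)cc1C(=O)N[C@H]1CCN(CC2CCN(C(=O)CC(C)C)CC2)C[C@H]1OC`, 78 nM in this assay

Compound 2 gives the lowest of the two numbers; its nearest neighbour is compound 1, which lies higher by a 4.8-fold lower number from compound 1 to compound 2 (0.68 log units; beyond the scatter). Compound 3, `CCC(=S)N1CCC(CN2CC[C@H](NC(=O)c3cc(Cl)c(N)cc3OC)[C@H](OC)C2)CC1`, differs from compound 2 by a group of 4 heavy atoms (3 carbon, 1 sulfur; no ring) in place of a group of 6 heavy atoms (5 carbon, 1 oxygen; no ring), on an amine nitrogen in a ring, on an amine nitrogen in a ring of a six-membered non-aromatic ring with one nitrogen. Among the measured compounds shown here, the only step that touches this position is the exchange of ethoxy for isobutyl on the carbonyl carbon, a 4.8-fold lower number from compound 1 to compound 2 (0.68 log units; beyond the scatter), a modest gain that the data do not explain. For the measured compounds named here, no measured step replaces the carbonyl oxygen by sulfur, so the direction for compound 3 rests on little. The expectation is a step of a 1.5-fold higher number from compound 2 to compound 3 (0.19 log units; within the scatter), staying close to the scatter. Compound 3 is estimated at 120 nM, within 40 nM to 400 nM.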

Compound 3, half-maximal inhibitory concentration: 593 nM
Beside the measured number, compound 3's estimate is 4.9-fold (0.69 log units) below it; the whole stated range lies below it.
By their numbers in this assay, from the lowest: compound 2; then compounds 1 and 3 (each within the scatter of the next).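

In this assay the group on the amine nitrogen of the six-membered ring turns out to matter in both directions, since replacing the isobutylcarbonyl with the group of 3 carbons and 1 sulfur gives a 7.6-fold higher number from compound 2 to compound 3 (0.88 log units; beyond the scatter) and undoes the gain seen earlier. Set against the ethoxycarbonyl group, the sulfur-containing group gives a 1.6-fold higher number from compound 1 to compound 3 (0.20 log units; within the scatter) and so cannot be told apart from it, leaving compound 2 as the only one of the three that stands out. Nothing measured here explains this pattern.

As far as these compounds go, compound 3 differs from compound 2 in both its chain and its sulfur, so the contribution of each remains unknown. A propanoyl group, with oxygen in place of the sulfur of compound 3, would separate the two, and a longer chain on the thiocarbonyl carbon would show whether chain length matters with sulfur present.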